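One Change at the Carbonyl: Expected Cell Tolerance

The source may report more compounds than this note shows. Statements on the series, on what has been measured and on what is new or still open speak of the compounds shown alone.

Compound 1 `Cc1cccc(C(=O)N(C)c2ccc(C(O)(C(F)(F)F)C(F)(F)F)cc2)c1`: 20000 nM
Compound 2 `O=C(c1ccccc1)N(Cc1ccccc1)c1ccc(C(O)(C(F)(F)F)C(F)(F)F)cc1`: 7500 nM

In an ADME assay on Li23 cells (Homo sapiens) for cytotoxicity, read by WST assay (a lower number here means that less compound is tolerated, a higher number that more compound is tolerated), compound 1 gives 20000 nM, the higher of the two numbers, so more of it is tolerated. Compound 2 gives 7500 nM, a lower number, and that gap lies beyond the scatter. Compound 3 `CN(C(=O)Nc1ccccc1)c1ccc(C(O)(C(F)(F)F)C(F)(F)F)cc1` has not yet been measured. It differs from compound 1 in one place: anilino in place of 3-methylphenyl on a carbonyl carbon. Among the measured compounds shown here, no measured pair shows this change, so no step is known for it. For compound 3 the expected step is none beyond the scatter, no change at the digits printed from compound 1 to compound 3 (within the scatter). Compound 3 is therefore estimated at 20000 nM, between 8000 nM and 50000 nM.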

Compound 3, half-maximal cytotoxic concentration: > 20000 nM
Compound 3: no number, only a limit; the forecaster's own chance of this, stated with the estimate: 20%; the middle value lies on the limit itself.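

In this assay compound 3 gives > 20000 nM, which is a limit of the assay and not a number. Anilino in place of 3-methylphenyl on a carbonyl carbon gives a number no lower from compound 1 to compound 3 (the limit leaves the size open), so the added hydrogen-bond donor at this position brings no sign of lower tolerance. The size of this step cannot be read, because the reading stops at a limit: the limit of > 20000 nM in this assay, at which 1 of the 3 values shown sits.

As far as these compounds go, what stays open is how a non-aromatic group on the same carbonyl carbon, such as a piperidine ring or a longer alkyl chain, would read in this assay.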